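From phenyl to 2-hydroxyethyl on the amide nitrogen

This account rests on a few compounds, and the source may have more. Where it says the series, first, only, none or still open, it means among the compounds named here.

In an ADME assay on Huh-7 cells (Homo sapiens) for cytotoxicity, read by a luciferase reporter and WST assay, with a stated time of 3 days (a lower number here means that less compound is tolerated, a higher number that more compound is tolerated), compound 2 (`O=C(Nc1ccccc1)c1c(NO)cc(-c2ccc(Cl)cc2)oc1=O`) gives 11000 nM, within the scatter of compound 1 (`O=C(Nc1ccccc1)c1c(NO)cc(-c2ccc(F)cc2)oc1=O`) at 10300 nM and compound 3 (`COc1ccc(-c2cc(NO)c(C(=O)Nc3ccccc3)c(=O)o2)cc1`) at 16200 nM. Compound 4 (`O=C(NCCO)c1c(NO)cc(-c2ccc(Cl)cc2)oc1=O`) has 2-hydroxyethyl in place of phenyl on an amide-type nitrogen. The measured steps, a 1.1-fold higher number from compound 1 to compound 2 (0.03 log units; within the scatter), a 1.6-fold higher number from compound 1 to compound 3 (0.20 log units; within the scatter) and a 1.5-fold higher number from compound 2 to compound 3 (0.17 log units; within the scatter), all exchange a group on an aromatic carbon, and all stay within the scatter. None touches the amide-type nitrogen, so they offer only a weak guide here. This larger exchange is tentatively expected to move this assay towards a higher number, beyond the scatter. The estimated change is a 2.7-fold higher number from compound 2 to compound 4 (0.44 log units; beyond the scatter). For compound 4 the expected value is 30000 nM, within an estimated range of 10000 nM to 100000 nM.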

Compound 4, half-maximal cytotoxic concentration: > 20000 nM
Compound 4 was reported as a limit (the forecaster's own chance of this, stated with the estimate: 25%); the middle value does not contradict the limit.
By their numbers in this assay, from the lowest: compounds 1, 2 and 3 (each within the scatter of the next). At a limit, above all of these: compound 4.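

Among the compounds shown here, compound 4 gives the first reading from a change on the amide-type nitrogen, as the earlier steps all exchanged a group on an aromatic carbon. In this assay compound 4 is reported only as a limit, > 20000 nM. Swapping phenyl for 2-hydroxyethyl here gives an at least 1.8-fold higher number from compound 2 to compound 4 (0.25 log units; that floor lies within the scatter), so losing the aromatic ring does not bring the number down, but the true size of the rise cannot be read.

Going by these compounds, it remains open whether the chain or its hydroxyl matters, which a plain ethyl group could test. On these data alone, a longer chain or an amine on this nitrogen also remains open.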